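The source may report more compounds than this note shows. Statements on the series, on what has been measured and on what is new or still open speak of the compounds shown alone.

Measured compounds:
Compound 1 `O=c1[nH]cnc2c1c(-c1cccs1)cn2[C@@H]1O[C@H](CO)[C@@H](O)[C@H]1O` gives > 20000 nM in a functional assay on K562 cells (Homo sapiens), read by MTT assay, with a stated time of 72 h (a higher number here means a weaker inhibitor, a lower number a stronger inhibitor), a limit of the assay and not a number.
Compound 2 `Cc1ncnc2c1c(-c1cc3ccccc3o1)cn2[C@@H]1O[C@H](CO)[C@@H](O)[C@H]1O` gives 19500 nM in this assay.
Compound 3 `Nc1nc2c(c(-c3cccs3)cn2[C@@H]2O[C@H](CO)[C@@H](O)[C@H]2O)c(=O)[nH]1` gives > 20000 nM in this assay, again a limit and not a number.

Compound 2 is the only one of the three with a numeric value in this assay; the other two sit at the limit, as the limit of > 20000 nM in this assay, at which 2 of the 3 values shown sit, records. Among the compounds with values here, the only step between measured compounds, a step that the two limits leave unreadable from compound 1 to compound 3, runs between two limits and cannot be read, and it does not touch the change studied here.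

Compound 4 `Cc1ncnc2c1c(-c1cccs1)cn2[C@@H]1O[C@H](CO)[C@@H](O)[C@H]1O` differs from compound 2 by thiophen-2-yl in place of 1-benzofuran-2-yl on an aromatic carbon. Within the data shown here, no measured pair shows this exchange on the core of compound 2. Compound 1 and compound 3 both carry thiophen-2-yl on a different core and give only limits, so no size or direction for the step can be drawn from them. Since compound 2 itself lies close to the limit, compound 4 is expected to remain weak, with the step of a 1.3-fold higher number from compound 2 to compound 4 (0.11 log units; within the scatter) expected to stay within or near the scatter. Compound 4 is estimated at 25000 nM, in the range 8000 nM to 80000 nM, with a fair chance that this assay reports only a limit.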

Compound 4, half-maximal inhibitory concentration: > 20000 nM
Compound 4: only a limit was reported (the forecaster's own chance of this, stated with the estimate: 60%); the middle value does not contradict the limit.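

In this assay compound 4 gives > 20000 nM, a limit of the assay and not a number. Within the data shown here, on the shared core, the exchange of 1-benzofuran-2-yl for thiophen-2-yl on this aromatic carbon of the five-membered ring, which no earlier pair could show, can now be read only as a floor: an at least 1.0-fold higher number from compound 2 to compound 4 (0.01 log units; that floor lies within the scatter) is all that the data give, so the exchange cannot be told apart from no change, although a larger step is not excluded. What it does show is that thiophen-2-yl, which lacks the six-membered aromatic ring of carbon, brings no readable gain in strength at this position, and the values gather further at the limit: the limit of > 20000 nM in this assay, at which 3 of the 4 values shown sit.

Among these compounds, the true size of this step remains unknown, and the step between the two limits among the earlier compounds cannot be read either. From the compounds shown here alone, whether a phenyl ring, an amine, a carboxylic acid or a longer chain on this aromatic carbon would bring the number in this assay clearly below that of compound 2 stays open, as does the effect of 1-benzofuran-2-yl on the core of compound 1.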